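Swapping the ring on the sulfonyl sulfur

A few compounds are considered here, and "the series" means these few. Any claim that something is new, unique, unknown or untested is made for them only; others in the source may bear on it.

Three measured compounds share one core. Compound 1 `O=S(=O)(c1cc(F)cc(F)c1)c1cnc2cc(F)ccc2c1-c1ccc(Cl)cc1` gives 0.03 mL/min in an ADME assay on microsomes from liver (Homo sapiens) for metabolic stability, tested at 2.5 uM; on this read-out lower numbers stand for slow clearance and higher numbers for fast clearance. Compound 2 `COc1cccc(-c2c(S(=O)(=O)c3cc(F)cc(F)c3)cnc3cc(F)ccc23)c1` gives 1.81 mL/min in this assay, and compound 3 `O=S(=O)(c1cc(F)cc(F)c1)c1cnc2cc(F)ccc2c1-c1cccc(F)c1` gives 0.06 mL/min in this assay. Compound 3 stands second highest of the three: its number lies within the scatter of compound 1, seen as a 2.0-fold higher number from compound 1 to compound 3 (0.30 log units; within the scatter), and far below compound 2, seen as a 30-fold lower number from compound 2 to compound 3 (1.48 log units; beyond the scatter). The large step of a 60-fold higher number from compound 1 to compound 2 (1.78 log units; beyond the scatter) concerns a methoxy entering the ring on the aromatic carbon, whereas exchanging one halogen for another on that same ring barely moved the number.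

Compound 4 `O=S(=O)(c1ccc(F)c(Cl)c1)c1cnc2cc(F)ccc2c1-c1cccc(F)c1` is not yet measured. It differs from compound 3 on the sulfonyl sulfur: 3-chloro-4-fluorophenyl in place of 3,5-difluorophenyl on a sulfonyl sulfur. Among the measured compounds shown here, none of the measured steps touches this ring; all three concern the ring on the aromatic carbon. The nearest guide is a 2.0-fold higher number from compound 1 to compound 3 (0.30 log units; within the scatter), where a chloro-for-fluoro exchange on the other ring stayed within the scatter. A halogen-for-halogen exchange here is therefore expected to give only a small step, a 1.3-fold higher number from compound 3 to compound 4 (0.12 log units; within the scatter), in this assay. The estimate for compound 4 is 0.08 mL/min, with a range from 0.03 mL/min to 0.25 mL/min.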

Compound 4, intrinsic clearance in a liver preparation (reported as CLH), per the amount of preparation that the assay uses: 0.25 mL/min
For compound 4 the middle estimate is 3.1-fold (0.49 log units) below the measured one; the measured number falls inside the stated range.
By their numbers in this assay, from the lowest: compounds 1 and 3 (each within the scatter of the next); then compound 4; then compound 2.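

The ring on the sulfonyl sulfur is not a silent place in this assay: 3-chloro-4-fluorophenyl in place of 3,5-difluorophenyl gives a 4.2-fold higher number from compound 3 to compound 4 (0.62 log units; beyond the scatter) even though both groups count the same number of heavy atoms and neither carries a hydrogen-bond donor or acceptor. Among the compounds shown here, the earlier steps all lay on the ring on the aromatic carbon, so this is the first sign that the number also responds to a change on the sulfonyl sulfur, and it shows that a swap among halogens can pass beyond the scatter here, unlike a 2.0-fold higher number from compound 1 to compound 3 (0.30 log units; within the scatter) on the other ring. No measurement shown here accounts for this rise.

Only one replacement on the sulfonyl sulfur appears, so the compounds shown cannot tell which of its differences counts: the chloro, or the new arrangement of the halogens. Also open, on these data alone, is how this ring would behave carrying an amine or a carboxylic acid instead of a halogen, and whether the same swap would give a similar step alongside the 3-methoxyphenyl group of compound 2.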